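The source may report more compounds than this note shows. Statements on the series, on what has been measured and on what is new or still open speak of the compounds shown alone.

Measured compounds:
compound 1, `Cc1cc(-c2nc3cc(F)ccc3o2)ccc1NC(=O)CCl`, 10500 nM
compound 2, `Cc1cc(-c2nc3ccccc3o2)ccc1NC(=O)CN1CCN(CCCN(C)C)CC1`, 33500 nM
compound 3, `O=C(CCl)Nc1ccc(-c2nc3cc(F)ccc3o2)cc1`, 9190 nM

The three measured compounds were tested in an ADME assay on NIH3T3 cells (Mus musculus) for cytotoxicity, read by MTT assay, with a stated time of 24 h; on this read-out higher numbers stand for weaker inhibition and lower numbers for stronger inhibition. Compound 1 gives 10500 nM, and compound 3 gives 9190 nM. Compound 1 and compound 3 differ by one change, (hydrogen in place of methyl on an aromatic carbon), and this gave a 1.1-fold lower number from compound 1 to compound 3 (0.06 log units; within the scatter). Compound 2 gives 33500 nM, which stands as the highest of the three numbers; its gap to compound 1 and to compound 3 is in each case beyond the scatter. The difference between the core of compound 2 and the core of compound 1 is not broken down here.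

Compound 4, `CN(C)CCCN1CCN(CC(=O)Nc2ccc(-c3nc4ccccc4o3)cc2)CC1`, has not been measured. It differs from compound 2 by hydrogen in place of methyl on an aromatic carbon. This is the same kind of change as that from compound 1 to compound 3, but not the same: in compound 1 the methyl sits ortho to a ((chloromethyl)carbonyl)amino group and meta to a large group, whereas in compound 2 it sits ortho to a large group and meta to a 1,3-benzoxazol-2-yl group. Among the measured compounds shown here, the one measured instance stayed within the scatter, so the step from compound 2 to compound 4 in this assay is expected to be small as well, a 1.1-fold lower number from compound 2 to compound 4 (0.03 log units; within the scatter), resting on the single pair that gave a 1.1-fold lower number from compound 1 to compound 3 (0.06 log units; within the scatter). Compound 4 is therefore estimated at 31000 nM, with a range from 14000 nM to 70000 nM.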

Compound 4, half-maximal inhibitory concentration: 16700 nM
Beside the measured number, compound 4's estimate is 1.9-fold (0.27 log units) above it; measured number inside the range.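

In this assay, hydrogen in place of methyl on an aromatic carbon, ortho to a large group and meta to a 1,3-benzoxazol-2-yl group, gave a 2.0-fold lower number from compound 2 to compound 4 (0.30 log units; within the scatter). Set beside the earlier instance of this change, the new step does not stand apart from it, so within this small set the change carries from one core to the other without a difference that can be told from the scatter: the same change on two cores in this assay, a 1.1-fold lower number (0.06 log units; within the scatter) from compound 1 to compound 3 and a 2.0-fold lower number (0.30 log units; within the scatter) from compound 2 to compound 4, 1.8-fold (0.24 log units) apart, within the scatter of two such steps. Among the compounds shown here, this rests on only two pairs in a single cell assay, so it shows neither that the methyl is without effect on every core of the series nor that the agreement would hold in any other assay or on a third core.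

The compounds shown leave open whether other groups on that same aromatic carbon, such as an ethyl, a methoxy or a chlorine, would behave as the methyl does. They also leave open whether the step would stay as small on a core whose side chain ends in a carboxylic acid rather than the dimethylamino group of compound 2, or on a core with a longer chain.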